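The source may report more compounds than this note shows. Statements on the series, on what has been measured and on what is new or still open speak of the compounds shown alone.

Compound 1 `COc1cc(-c2cc(/C=C/C(=O)c3ccc(Cl)c(Cl)c3)[nH]n2)cc(OC)c1OC` gives 9830 nM in a functional assay on SNB-19 cells (Homo sapiens) for inhibition, read by sulforhodamine B assay, with a stated time of 48 h; on this read-out higher numbers stand for weaker inhibition of growth and lower numbers for stronger inhibition of growth.
Compound 2 `COc1ccc(C(=O)/C=C/c2cc(-c3cc(OC)c(OC)c(OC)c3)n[nH]2)cc1OC` gives 1420 nM in this assay.
Compound 3 `COc1cc(-c2cc(/C=C/C(=O)c3ccc(F)c(F)c3)[nH]n2)cc(OC)c1OC` gives 3640 nM in this assay.

Compound 2 stands lowest of the three, with a 6.9-fold lower number from compound 1 to compound 2 (0.84 log units; beyond the scatter) and a 2.6-fold higher number from compound 2 to compound 3 (0.41 log units; beyond the scatter) both beyond the scatter. Compound 4 `COc1cc(C(=O)/C=C/c2cc(-c3cc(OC)c(OC)c(OC)c3)n[nH]2)cc(OC)c1OC` differs from compound 2 by methoxy in place of hydrogen on an aromatic carbon. Within the data shown here, no measured step makes this same change; the steps that concern the same ring on the carbonyl carbon are a 6.9-fold lower number from compound 1 to compound 2 (0.84 log units; beyond the scatter), a 2.7-fold lower number from compound 1 to compound 3 (0.43 log units; beyond the scatter) and a 2.6-fold higher number from compound 2 to compound 3 (0.41 log units; beyond the scatter), each modest. A step of similar or smaller size is therefore expected, direction uncertain, and a 1.4-fold lower number from compound 2 to compound 4 (0.15 log units; within the scatter) is the estimate. Compound 4 is expected to give about 1000 nM in this assay, within a range from 300 nM to 4000 nM.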

Compound 4, concentration for 50% growth inhibition: 1660 nM
Compound 4: the middle estimate sits 1.7-fold (0.22 log units) below what was measured, within the range that was stated.
By their numbers in this assay, from the lowest: compounds 2 and 4 (each within the scatter of the next); then compound 3; then compound 1.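

The added methoxy in place of hydrogen, ortho to a methoxy group, gives a 1.2-fold higher number from compound 2 to compound 4 (0.07 log units; within the scatter) in this assay and so leaves no readable change at this position. The earlier steps shown here each exchanged the whole ring on the carbonyl carbon and lay beyond the scatter, whereas this single addition to that ring does not. Nothing available offers an explanation for this result.

The compounds shown leave open whether an amine, a hydroxyl or a longer chain such as ethoxy at this same position would also stay within the scatter.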